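The source may hold more compounds than are shown below. What is called first, only, known or untested is meant among the compounds shown, and "the series" means these compounds.

Measured so far:
- compound 1 `COc1cc(C(C)=O)ccc1OCCCCCN1CCC(C(c2ccc(F)cc2)c2ccc(F)cc2)CC1`: 3.16 nM
- compound 2 `COc1cc(C(C)=O)ccc1OCCCN1CCC(C(C(N)=O)(c2ccc(F)cc2)c2ccc(F)cc2)CC1`: 25.1 nM

In a functional assay (aorta) with Oryctolagus cuniculus as the target (on this read-out higher numbers stand for weaker binding and lower numbers for tighter binding), compound 2 stands at 25.1 nM, the higher number of the two, against compound 1 at 3.16 nM, a gap beyond the usual scatter. Compound 3 `COc1cc(C(C)=O)ccc1OCCCN1CCC(C(NC(C)=O)(c2ccc(F)cc2)c2ccc(F)cc2)CC1` has acetamido in place of carbamoyl on a saturated chain carbon bound to two aromatic carbons and a saturated ring carbon. Within the data shown here, no measured pair differs in only one place, so no earlier step can guide the expectation. The expected change, a 1.3-fold higher number from compound 2 to compound 3 (0.11 log units; within the scatter), stays within the scatter, with no firm direction. For compound 3 the estimated value is 32 nM, with an expected range of 10 nM to 100 nM.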

Compound 3, dissociation constant: 63.1 nM
Beside the measured number, compound 3's estimate is 2.0-fold (0.29 log units) below it, within the range that was stated.
By their numbers in this assay, from the lowest: compound 1; then compound 2; then compound 3.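

In this assay, among these compounds, this is the first single-place comparison at this saturated chain carbon: acetamido in place of carbamoyl gives a 2.5-fold higher number from compound 2 to compound 3 (0.40 log units; beyond the scatter). The change therefore shifts the read-out modestly, although the two groups match in hydrogen-bond donors and acceptors. Nothing available explains the shift.

As far as these compounds go, how an amine or a carboxylic acid on this same carbon would compare remains open. From the compounds shown here alone, this step also comes from a single pair, so whether it would hold with a longer chain in the shared core is unknown.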